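The compounds below may be only part of what the source reports. "The series", "measured", "known", "first", "only" and "open" are said of these compounds alone.

Compound 2 `c1cnc(NCc2ccc(CNc3ccccc3N3CCCC3)cc2)nc1` gives 100 nM in an assay on MDA-MB-231 cells for displacement of a labelled ligand from C-X-C chemokine receptor type 4 (Homo sapiens); a lower number here means that less compound is needed, a higher number that more compound is needed for the effect. In that assay compound 3 `Fc1cccc(NCc2ccc(CNc3cccc(F)n3)cc2)n1` gives 100 nM, level with compound 2 at the digits shown and within the scatter, so no order between the two can be stated; together they carry the highest numbers of the three. Compound 1 `COc1ncc(F)c(NCc2ccc(CNc3nc(OC)ncc3F)cc2)n1` gives 1 nM in this assay, a far lower number than compound 2. Compound 4 `c1ccc(NCc2ccc(CNc3ncccn3)cc2)cc1` has not yet been measured. It differs from compound 2 in one place: hydrogen in place of pyrrolidin-1-yl on an aromatic carbon. For the measured compounds named here, no measured pair shows this change, so its size is an open question. Since the groups on the outer rings appear to matter, given the gap from compound 1 to compound 2, compound 4 is expected to move upward by a 3.0-fold higher number from compound 2 to compound 4 (0.48 log units; beyond the scatter). Compound 4 is therefore estimated at 300 nM, within 80 nM to 1500 nM.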

Compound 4, effective concentration (reported as EC, without a stated level of effect): 10 nM
Compound 4: middle estimate off by 30-fold (1.48 log units), on the high side, and the stated range ends above it.
By their numbers in this assay, from the lowest: compound 1; then compound 4; then compounds 2 and 3 (each within the scatter of the next).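

In this assay, the first one-place change available shows that this aromatic carbon is sensitive to substitution: hydrogen in place of pyrrolidin-1-yl gives a 10-fold lower number from compound 2 to compound 4 (1.00 log units; beyond the scatter). The large group is therefore not required for a low number in this pair. No measurement shown accounts for the size of this step.

On these data alone, it remains open whether a methyl or a dimethylamino group on this carbon would give a number closer to that of compound 4 or of compound 2. A single pair also cannot show whether the same change would have a similar effect on other cores.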